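Cytotoxicity notes on a dihydroxypyrimidine carboxamide series

The source may report more compounds than this note shows. Statements on the series, on what has been measured and on what is new or still open speak of the compounds shown alone.

Measured so far:
- compound 1, `Cc1ccc(CNC(=O)c2nc(C(C)(C)NC(=O)OCc3ccccc3)nc(O)c2O)cc1`: 234000 nM
- compound 2, `CC(C)(NC(=O)OCc1ccccc1)c1nc(O)c(O)c(C(=O)NCc2ccc(C(F)(F)F)cc2)n1`: 58100 nM
- compound 3, `COCCNC(=O)Nc1nc(C(C)(C)NC(=O)OCc2ccccc2)nc(O)c1O`: > 500000 nM

The read-out throughout is an ADME assay on C8166 cells (Homo sapiens) for cytotoxicity, read by MTT assay, with a stated time of 3 days; a higher number here means that more compound is tolerated, a lower number that less compound is tolerated. Going by the values given here, compound 1 gives 234000 nM and compound 2 gives 58100 nM in this assay; the change a 4.0-fold lower number from compound 1 to compound 2 (0.61 log units; beyond the scatter) is the only step with a full number at both ends. For compound 3 the value > 500000 nM is a limit of the assay, not a number, as the limit of > 500000 nM in this assay, at which 1 of the 3 values shown sits, records. Compound 3 therefore stands at the high end of the three, with the step of an at least 2.1-fold higher number from compound 1 to compound 3 (0.32 log units; beyond the scatter) known only as a minimum.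

Compound 4 is `CC(C)(NC(=O)OCc1ccccc1)c1nc(O)c(O)c(C(=O)NCc2ccccc2)n1`. Its difference from compound 3 is benzylcarbamoyl in place of ((2-methoxyethyl)carbamoyl)amino on an aromatic carbon. This change essentially reverses the step from compound 1 to compound 3, except that the benzyl group entering carries no methyl. The measured step of an at least 2.1-fold higher number from compound 1 to compound 3 (0.32 log units; beyond the scatter) bears on it directly; compound 2 shows that a change on the benzyl ring can shift the number by a 4.0-fold lower number from compound 1 to compound 2 (0.61 log units; beyond the scatter). In this assay the expected step is therefore downward, at least modest, an at least 2.1-fold lower number from compound 3 to compound 4 (0.33 log units; beyond the scatter). Compound 4 is estimated at 230000 nM, with a range from 90000 nM to 500000 nM.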

Compound 4, half-maximal cytotoxic concentration: 41400 nM
Compound 4: the middle estimate sits 5.6-fold (0.74 log units) above what was measured; the measured number lies below the stated range.
By their numbers in this assay, from the lowest: compounds 4 and 2 (each within the scatter of the next); then compound 1. At a limit, above all of these: compound 3.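

In this assay, the step of an at least 12-fold lower number from compound 3 to compound 4 (1.08 log units; beyond the scatter) shows that the exchange of ((2-methoxyethyl)carbamoyl)amino for benzylcarbamoyl at this position is large, and that the minimum carried over from compound 1 understated how much the number can move here. The step of a 5.7-fold lower number from compound 1 to compound 4 (0.75 log units; beyond the scatter) shows that the methyl on the benzyl ring also matters, since its loss gives a modest drop, whereas a 1.4-fold lower number from compound 2 to compound 4 (0.15 log units; within the scatter) stays within the scatter. Compounds 2 and 4 therefore read alike with trifluoromethyl or hydrogen on that ring, so the earlier step from compound 1 to compound 2 marks compound 1 as the one that stands apart among the benzyl amides, not trifluoromethyl as a group that lowers the number.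

The compounds shown leave open whether the gap to compound 3 follows the 2-methoxyethyl chain, the amino link or the loss of the benzyl ring, and whether an amine or a carboxylic acid on that ring would behave like methyl or like hydrogen. The size of the largest step also stays open, as compound 3 is held at a limit of the assay and not a number: the limit of > 500000 nM in this assay, at which 1 of the 4 values shown sits.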